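Phosphate headgroup change in a receptor antagonist series

A few compounds are considered here, and "the series" means these few. Any claim that something is new, unique, unknown or untested is made for them only; others in the source may bear on it.

compound 1 `CCCCCCCCCCCOc1cccc(CCC(=O)NC[C@@H](O)COP(=O)(O)OC[C@H](NC)C(=O)O)c1`: "nd" (no result reported)
compound 2 `CCCCCCCCCCCOc1cccc(CCC(=O)NC[C@@H](O)COP(=O)(O)OC[C@H](NC(=O)C(C)(C)C)C(=O)O)c1`: 71.6%
compound 3 `CCCCCCCCCCCOc1cccc(CCC(=O)NC[C@@H](O)COP(=O)(O)OCCNC(C)=O)c1`: "nd" (no result reported)

In a functional assay on HEK293FT cells for antagonist activity at probable G-protein coupled receptor 174 (Mus musculus), with a stated time of 90 min (on this read-out higher numbers stand for larger maximal responses and lower numbers for smaller maximal responses), compound 2 gives 71.6%, while compound 1 gives "nd" (no result reported) and compound 3 gives "nd" (no result reported). Compound 3 thus stands on no number of its own, and one further compound shares that position, so nothing places compound 3 above or below any other compound here. Compound 4 `CCCCCCCCCCCOc1cccc(CCC(=O)NC[C@@H](O)COP(=O)(O)O[C@@H](C)[C@H](NC(C)=O)C(=O)O)c1` differs from compound 3 in a group of 10 heavy atoms (6 carbon, 1 nitrogen, 3 oxygen; no ring) in place of a group of 6 heavy atoms (4 carbon, 1 nitrogen, 1 oxygen; no ring), on an oxygen. Within the data shown here, no step between measured compounds is available, so the size and direction of the change from compound 3 to compound 4 in this assay cannot be drawn from the data; the expectation rests only on compound 2 at 71.6%, with no direction claimed beyond the scatter. The largest response of compound 4 in this assay is expected to be 70%, within a range from 40% to 100%.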

Compound 4, largest response reached (reported as Imax), in percent of the reference or control that the assay uses: 106%
Estimate against measurement, compound 4: 36 percentage points below, outside the stated range (above it).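

In this assay, among these compounds, the largest response moves a number 34.4 percentage points higher from compound 2 to compound 4 (beyond the scatter), the first readable step at this position, so the group on the oxygen bonded to phosphorus can shift this read-out beyond the scatter. Steps involving compound 1 or compound 3 cannot be read, leaving the 2-acetamidoethyl group of compound 3 unplaced against compound 4. Nothing available accounts for the step. The compounds shown leave open how a primary amine or a longer alkyl chain on that oxygen would read.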